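The compounds below may be only part of what the source reports. "The series", "measured", "known", "first", "only" and "open" are said of these compounds alone.

Working notes on the series, anticancer screen.

Compound 1 `O=C(Nc1ccc(Cl)c(-c2nnc3c(Cl)cccn23)c1)c1ccc(F)cc1Cl` is the reference. In a functional assay on A549 cells (Homo sapiens) for antiproliferative activity, read by MTT assay, with a stated time of 72 h (on this read-out lower numbers stand for stronger inhibition and higher numbers for weaker inhibition), compound 1 gives only a limit of the assay, > 100000 nM, so its true number is not known. The two measured neighbours carry a different aryl group on the carbonyl carbon: compound 2 `O=C(Nc1ccc(Cl)c(-c2nnc3c(Cl)cccn23)c1)c1cccc(Cl)c1` gives 52700 nM in this assay, and compound 3 `O=C(Nc1ccc(Cl)c(-c2nnc3c(Cl)cccn23)c1)c1cccnc1Cl` gives 35800 nM. The step of an at least 1.8-fold lower number from compound 1 to compound 2 (0.27 log units; that floor lies within the scatter) and the step of an at least 2.7-fold lower number from compound 1 to compound 3 (0.44 log units; beyond the scatter) both run downward from the limit, though the first floor lies within the scatter. Between the two measured neighbours the step of a 1.5-fold lower number from compound 2 to compound 3 (0.17 log units; within the scatter) is within the scatter.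

Compound 4 `O=C(Nc1ccc(Cl)c(-c2nnc3c(Cl)cccn23)c1)c1ccccc1Cl` is not yet measured. It differs from compound 1 by hydrogen in place of fluoro on an aromatic carbon. Among the measured compounds shown here, no measured step in this set removes only a fluoro on that ring; the steps from compound 1 change the whole aryl group, and they suggest that compound 1 sits at the weak end, with neighbours a little below the limit. A small downward step or none beyond the scatter is therefore the expectation for compound 4, with a real chance that this assay again returns only a limit. The expected step is an at least 1.4-fold lower number from compound 1 to compound 4 (0.15 log units; that floor lies within the scatter) from compound 1 to compound 4, taken from the limit value. The estimate for compound 4 in this assay is 70000 nM, with a range from 30000 nM to 200000 nM.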

Compound 4, half-maximal inhibitory concentration: > 100000 nM
Compound 4 gave a limit, no number; the forecaster's own chance of this, stated with the estimate: 40%; at least 1.4-fold (0.15 log units) between middle value and limit.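

In this assay compound 4 returns only a limit, as compound 1 does, so hydrogen in place of fluoro on this aromatic carbon does not bring the series into a readable range, and the step between the two cannot be read: the limit of > 100000 nM in this assay, at which 2 of the 4 values shown sit.

Fluoro at this place is therefore not what holds compound 1 at the limit, as the 2-chlorophenyl group sits at the same limit without it. Against the measured neighbours the new compound shows an at least 2.7-fold higher number from compound 3 to compound 4 (0.44 log units; beyond the scatter), and also an at least 1.8-fold higher number from compound 2 to compound 4 (0.27 log units; that floor lies within the scatter), so only the 2-chloropyridin-3-yl group stands clearly apart from 2-chlorophenyl, while the 3-chlorophenyl comparison remains unsettled.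

The compounds shown leave open whether fluoro has any effect on this read-out, as any difference between compound 1 and compound 4 would lie beyond the reach of the assay. Also open, as far as these compounds go, is whether another group on this aromatic carbon, such as an amine, a methoxy group or a carboxylic acid, would give the 2-chlorophenyl amide a measurable number.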